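Benzothiazolyl-aminopyrimidine sulfonyl series: methoxy to fluoro exchange

The compounds below may be only part of what the source reports. "The series", "measured", "known", "first", "only" and "open" are said of these compounds alone.

Working notes on the series. Going by the values given here, compound 3 `COc1ccc2nc(Nc3ccnc(Nc4ccc(S(N)(=O)=O)cc4)n3)sc2c1` is the only member with a numerical reading in a functional assay on MCF7 cells (Homo sapiens) for antiproliferative activity, read by MTT assay, with a stated time of 48 h; on this read-out lower numbers stand for stronger inhibition and higher numbers for weaker inhibition; there compound 3 gives 11000 nM. Compound 2 `COc1ccc2nc(Nc3nc(Nc4ccc(S(N)(=O)=O)cc4)ncc3F)sc2c1` sits at a limit of the assay: in this assay compound 2 gives > 50000 nM. Compound 1 `CS(=O)(=O)c1ccc(Nc2nccc(Nc3nc4ccc(F)cc4s3)n2)cc1` likewise sits at a limit: in this assay compound 1 gives > 60000 nM. Among the compounds with values here, the single measured step, an at least 4.5-fold lower number from compound 2 to compound 3 (0.65 log units; beyond the scatter), concerns hydrogen in place of fluoro on an aromatic carbon and says nothing about the methoxy group. Compound 4 `NS(=O)(=O)c1ccc(Nc2nccc(Nc3nc4ccc(F)cc4s3)n2)cc1` differs from compound 3 by fluoro in place of methoxy on an aromatic carbon. Compound 1 carries that same fluoro on the fused system together with a different sulfonyl group, and its reading is a limit (the limit of > 60000 nM in this assay, at which 1 of the 3 values shown sits). Within the data shown here, no measured pair isolates the methoxy-to-fluoro exchange, so the expectation rests on the generally weak standing of the set. Compound 4 is expected to give 30000 nM (range 10000 nM to 100000 nM) in this assay, an estimated step of a 2.7-fold higher number from compound 3 to compound 4 (0.44 log units; beyond the scatter) toward weaker inhibition, with a real chance that only a limit is reported.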

Compound 4, half-maximal inhibitory concentration: 10900 nM
Estimate against measurement, compound 4: 2.8-fold (0.44 log units) above; the range from low to high includes it.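

In this assay the exchange of methoxy for fluoro, on an aromatic carbon of the six-membered aromatic ring of carbon only, now has a measured pair: a 1.0-fold lower number from compound 3 to compound 4 (0.00 log units; within the scatter), so this position shows no difference between the two groups on this read-out. The group on the sulfonyl sulfur, in contrast, shows a change beyond the scatter, with amino in place of methyl giving an at least 5.5-fold lower number from compound 1 to compound 4 (0.74 log units; beyond the scatter). Compound 1 stands at a limit of the assay, so the size of that step is a bound and not a number: the limit of > 60000 nM in this assay, at which 1 of the 4 values shown sits.

As far as these compounds go, whether the same indifference holds at this position for other groups, such as a hydroxyl or a longer alkoxy chain, stays open. Also open, from the compounds shown here alone, is how a substituted amine such as methylamino or dimethylamino on the sulfonyl sulfur would read.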